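From Penta-1,3-dien-1-yl to Pent-1-en-1-yl

A few compounds are considered here, and "the series" means these few. Any claim that something is new, unique, unknown or untested is made for them only; others in the source may bear on it.

In a functional assay on HCT-116 cells (Homo sapiens) for inhibition, read by MTT assay, with a stated time of 48 h (a higher number here means a weaker inhibitor, a lower number a stronger inhibitor), compound 1 (`COCC(=O)N(Cc1ccc(OC)c(O)c1)c1cc(OC)c(OC)c(OC)c1`) gives 230 nM and compound 2 (`C/C=C/C=C/C(=O)N(Cc1ccc(OC)c(O)c1)c1cc(OC)c(OC)c(OC)c1`) gives 180 nM. Going by the values given here, compound 2 therefore stands level with compound 1, the only other measured compound, within the scatter. Compound 3 (`CCC/C=C/C(=O)N(Cc1ccc(OC)c(O)c1)c1cc(OC)c(OC)c(OC)c1`) keeps the core of compound 2 and differs in one place: propyl in place of prop-1-en-1-yl on a double-bonded chain carbon bound to a double-bonded chain carbon. Among the compounds with values here, the one measured step that bears on this change is a 1.3-fold lower number from compound 1 to compound 2 (0.11 log units; within the scatter), which put penta-1,3-dien-1-yl in place of methoxymethyl on a carbonyl carbon and stayed within the scatter. No step beyond the scatter is therefore expected in this assay. The estimated step is a 1.1-fold higher number from compound 2 to compound 3 (0.05 log units; within the scatter). Compound 3 is expected to give about 200 nM, with an estimated range from 75 nM to 530 nM.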

Compound 3, half-maximal inhibitory concentration: 95 nM
Compound 3: middle estimate off by 2.1-fold (0.32 log units), on the high side; the measured number falls inside the stated range.
By their numbers in this assay, from the lowest: compounds 3, 2 and 1 (each within the scatter of the next, the first and the last beyond it).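

Putting propyl in place of prop-1-en-1-yl on a double-bonded chain carbon bound to a double-bonded chain carbon removes one double bond outside aromatic rings and gives a 1.9-fold lower number from compound 2 to compound 3 (0.28 log units; within the scatter) in this assay, so the activity of compound 2 in this assay does not depend on that double bond. Pent-1-en-1-yl in place of methoxymethyl on a carbonyl carbon gives a 2.4-fold lower number from compound 1 to compound 3 (0.38 log units; beyond the scatter), the first step in this series to pass the scatter, whereas penta-1,3-dien-1-yl in that place stayed within it. Nothing available explains the size of either step.

From the compounds shown here alone, it remains open whether the double bond left in compound 3 matters, as a fully saturated pentyl group would show. Also open, going by these compounds, is how a longer chain, or a chain ending in an amine or a carboxylic acid, would read here.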